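This account rests on a few compounds, and the source may have more. Where it says the series, first, only, none or still open, it means among the compounds named here.

Measured so far in a functional assay on BCG823 cells (Homo sapiens) for inhibition, read by MTT assay, with a stated time of 72 h; on this read-out lower numbers stand for stronger inhibition and higher numbers for weaker inhibition:

- compound 1, `CNc1nc(C(F)(F)F)c(C(=O)N/N=C/c2cccc(C(F)(F)F)c2)s1`: > 100 ug/mL, which is a limit of this assay rather than a number
- compound 2, `CN(C(=O)NC(=O)c1ccccc1F)c1nc(C(F)(F)F)c(C(=O)N/N=C/c2cccc(C(F)(F)F)c2)s1`: 16.3 ug/mL
- compound 3, `CN(C(=O)NC(=O)c1ccccc1F)c1nc(C(F)(F)F)c(C(=O)N/N=C/c2ccc(C(F)(F)F)cc2)s1`: 3.87 ug/mL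

The two cores of compound 2 and compound 3 differ in one place, (4-(trifluoromethyl)phenyl in place of 3-(trifluoromethyl)phenyl on a carbon with a double bond to nitrogen). That change alone gives a 4.2-fold lower number from compound 2 to compound 3 (0.62 log units; beyond the scatter), so compound 3 sits at the lowest number among the measured pair; the value of compound 1 is a limit and does not rank (the limit of > 100 ug/mL in this assay, at which 1 of the 3 values shown sits).

The second change seen in the series is hydrogen in place of ((2-fluorophenyl)carbonyl)carbamoyl on a nitrogen on an aromatic ring. It gives an at least 6.1-fold higher number from compound 2 to compound 1 (0.78 log units; beyond the scatter), the size of the step being open at the upper end because compound 1 sits at the limit (the limit of > 100 ug/mL in this assay, at which 1 of the 3 values shown sits).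

Compound 4, `CNc1nc(C(F)(F)F)c(C(=O)N/N=C/c2ccc(C(F)(F)F)cc2)s1`, is not yet measured in this assay. It differs from compound 3 by hydrogen in place of ((2-fluorophenyl)carbonyl)carbamoyl on a nitrogen on an aromatic ring. This is the same change as that from compound 2 to compound 1, made at the same place on the same kind of neighbourhood, but on the core of compound 3.

For compound 4 a step of about a 10-fold higher number from compound 3 to compound 4 (1.01 log units; beyond the scatter) is expected in this assay, resting on the step of an at least 6.1-fold higher number from compound 2 to compound 1 (0.78 log units; beyond the scatter) and on the limit at which compound 1 sits (the limit of > 100 ug/mL in this assay, at which 1 of the 3 values shown sits). Starting from the lower number of compound 3 (3.87 ug/mL), the number for compound 4 is estimated at 40 ug/mL. For compound 4 the expected range runs from 12 ug/mL to 150 ug/mL. It is quite possible that compound 4, like compound 1, returns only a limit.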

Compound 4, half-maximal inhibitory concentration: > 100 ug/mL
Compound 4 gave a limit, no number; the forecaster's own chance of this, stated with the estimate: 40%; middle value at least 2.5-fold (0.39 log units) away from the limit.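

In this assay, hydrogen in place of ((2-fluorophenyl)carbonyl)carbamoyl on the aromatic-ring nitrogen gives an at least 25-fold higher number from compound 3 to compound 4 (1.41 log units; beyond the scatter), a large step towards weaker inhibition. Compound 4 returns a limit of the assay rather than a number, and it is not alone there: the limit of > 100 ug/mL in this assay, at which 2 of the 4 values shown sit. Carried to a second core, the change goes the same way, so on these two cores the ((2-fluorophenyl)carbonyl)carbamoyl group goes with the measurable numbers and its loss with the limit, but nothing shows that the size of the step carries over: the same change on two cores in this assay, an at least 6.1-fold higher number (0.78 log units; beyond the scatter) from compound 2 to compound 1 and an at least 25-fold higher number (1.41 log units; beyond the scatter) from compound 3 to compound 4; the limit leaves it open whether they differ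

Among the compounds shown, only hydrogen and the whole ((2-fluorophenyl)carbonyl)carbamoyl group stand on that nitrogen, so it remains open whether a plain acetyl, an unsubstituted benzoyl or a simple carbamoyl would keep the lower numbers, and which part of the group the step depends on. The two cores also differ only between 3-(trifluoromethyl)phenyl and 4-(trifluoromethyl)phenyl, which leaves open how the change behaves on a core with a different group in their place, such as a phenyl bearing a nitrile, an amine or a carboxylic acid.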